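The compounds below may be only part of what the source reports. "The series", "measured", "known", "first", "only" and "open" are said of these compounds alone.

- compound 1 `Cc1ccc(NS(=O)(=O)c2ccc(N3CCNC3=O)cc2)cc1C` gives 230 nM in the measurements so far
- compound 2 `CCc1ccc(NS(=O)(=O)c2ccc(N3CCNC3=O)cc2)cc1` gives 810 nM in the measurements so far

In a functional assay on MCF7 cells (Homo sapiens) for antiproliferative activity, read by sulforhodamine B assay, with a stated time of 48 h (on this read-out higher numbers stand for weaker inhibition and lower numbers for stronger inhibition), compound 2 stands at 810 nM as the higher of the two numbers. Compound 3 `O=C1NCCN1c1ccc(S(=O)(=O)Nc2ccc(F)c(F)c2)cc1` has 3,4-difluorophenyl in place of 4-ethylphenyl on a sulfonamide nitrogen. Among the compounds with values here, the only measured step at that place is a 3.5-fold higher number from compound 1 to compound 2 (0.55 log units; beyond the scatter) and it is modest. Neither measured compound carries fluorine, so this step is only a loose guide. In this assay a similarly modest move to a higher number is expected, with the estimated step being a 2.5-fold higher number from compound 2 to compound 3 (0.39 log units; beyond the scatter) at low confidence. Compound 3 is estimated at 2000 nM with 500 nM to 8000 nM as its expected range.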

Compound 3, half-maximal inhibitory concentration: 620 nM
Estimate against measurement, compound 3: 3.2-fold (0.51 log units) above; measured number inside the range.
By their numbers in this assay, from the lowest: compound 1; then compounds 3 and 2 (each within the scatter of the next).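

In this assay, 3,4-difluorophenyl and 4-ethylphenyl on a sulfonamide nitrogen are not told apart, with a 1.3-fold lower number from compound 2 to compound 3 (0.12 log units; within the scatter). Compound 1 alone separates from the others, now also with a 2.7-fold higher number from compound 1 to compound 3 (0.43 log units; beyond the scatter), so 3,4-dimethylphenyl gives the lowest number of the three groups. Nothing measured here explains this difference. As far as these compounds go, how a plain phenyl, 4-methoxyphenyl or 4-aminophenyl on a sulfonamide nitrogen would compare remains open. So does whether the 3,4-dimethylphenyl result would hold with any change to the rest of the shared core.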